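Hydroxamate-linked diaryl ureas: estimate for compound 3

The source may hold more compounds than are shown below. What is called first, only, known or untested is meant among the compounds shown, and "the series" means these compounds.

Compound 1 `COc1cc2c(Oc3ccc(NC(=O)Nc4ccccc4Cl)cc3)ccnc2cc1OCCCCCCC(=O)NO`: 1910 nM
Compound 2 `COc1cc2c(Oc3ccc(NC(=O)Nc4ccc(C)cc4C)cc3)ccnc2cc1OCCCCCCC(=O)NO`: 5490 nM

Among the compounds with values here, in a functional assay on A549 cells (Homo sapiens) for antiproliferative activity, read by MTT assay (a lower number here means a stronger inhibitor, a higher number a weaker inhibitor), compound 1 stands lowest of the two numbers; the only measured step, a 2.9-fold higher number from compound 1 to compound 2 (0.46 log units; beyond the scatter), is modest. Compound 3 `COc1cc2c(Oc3ccc(NC(=O)NNC(=O)c4ccccc4)cc3)ccnc2cc1OCCCCCCC(=O)NO` differs from compound 1 in one place: benzamido in place of 2-chlorophenyl on an amide-type nitrogen. The measured step exchanges one aryl for another on the same nitrogen, so it bears only loosely on this larger change, which brings a hydrogen-bond donor and acceptor into the place. A weakening of similar or somewhat greater size is expected here. Compound 3 is estimated at 4000 nM, range 1300 nM to 12000 nM. That estimate means an expected step of a 2.1-fold higher number from compound 1 to compound 3 (0.32 log units; beyond the scatter).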

Compound 3, half-maximal inhibitory concentration: 2820 nM
Compound 3: the middle estimate sits 1.4-fold (0.15 log units) above what was measured, and the stated range covers the measured number.
By their numbers in this assay, from the lowest: compounds 1, 3 and 2 (each within the scatter of the next, the first and the last beyond it).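

In this assay benzamido on the amide-type nitrogen gives a 1.5-fold higher number from compound 1 to compound 3 (0.17 log units; within the scatter) against 2-chlorophenyl and a 1.9-fold lower number from compound 2 to compound 3 (0.29 log units; within the scatter) against 2,4-dimethylphenyl in this series. The position therefore tolerates more than an aryl group carried directly on the nitrogen: a carbonyl and an amide hydrogen enter here with neither step beyond the scatter. Nothing available explains this tolerance.

From the compounds shown here alone, whether cyclohexyl or benzyl would fit this place equally remains open. Also open, going by these compounds, is whether a chlorine or methyl on the benzamido ring would move the number.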